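The source may hold more compounds than are shown below. What is called first, only, known or untested is meant among the compounds shown, and "the series" means these compounds.

In a functional assay on MV4-11 cells (Homo sapiens) for antiproliferative activity, read by CellTiter-Glo, with a stated time of 72 h (on this read-out lower numbers stand for stronger inhibition of growth and higher numbers for weaker inhibition of growth), the compounds read as follows:
- Compound 1 `COCCN[C@H]1CC[C@H](Nc2cc(-c3csc(NCC4CCOCC4)n3)c(C)cn2)CC1` gives 1620 nM
- Compound 2 `CNc1nc(-c2cc(N[C@H]3CC[C@H](NCCOC)CC3)ncc2Cl)cs1` gives 530 nM
- Compound 3 `COCCN[C@H]1CC[C@H](Nc2cc(-c3csc(NCC4CC4)n3)c(Cl)cn2)CC1` gives 740 nM

Compound 3 (at 740 nM) stands within the scatter of compound 2, while compound 1 (at 1620 nM) gives a higher number, beyond the scatter.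

Compound 4 `COCCN[C@H]1CC[C@H](Nc2cc(-c3csc(NCC4CCCCC4)n3)c(Cl)cn2)CC1` has cyclohexyl in place of cyclopropyl on a saturated chain carbon bound to a nitrogen on an aromatic ring.

Among the measured compounds shown here, one measured step bears on this place. That step, a 1.4-fold higher number from compound 2 to compound 3 (0.14 log units; within the scatter), brought in cyclopropyl in place of hydrogen and stayed small. Compound 1 differs from compound 3 in more than one place, so it isolates nothing. For the measured compounds named here, no measured step shows cyclohexyl itself.

In this assay no step beyond the scatter is therefore expected, and the estimated move is a 1.1-fold higher number from compound 3 to compound 4 (0.03 log units; within the scatter) with only a slight lean to a higher number. For compound 4 the estimated value is 800 nM (350 nM to 1800 nM).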

Compound 4, concentration for 50% growth inhibition: 820 nM
Compound 4: the middle estimate sits 1.0-fold (0.01 log units) below what was measured; the range from low to high includes it.
By their numbers in this assay, from the lowest: compounds 2, 3, 4 and 1 (each within the scatter of the next, the first and the last beyond it).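

In this assay the larger ring changes little: cyclohexyl in place of cyclopropyl on a saturated chain carbon bound to a nitrogen on an aromatic ring gives a 1.1-fold higher number from compound 3 to compound 4 (0.04 log units; within the scatter) and stays within the scatter. Measured against hydrogen at the same place, the step is a 1.5-fold higher number from compound 2 to compound 4 (0.19 log units; within the scatter) and also stays within the scatter. Compound 2, compound 3 and compound 4 therefore read alike with hydrogen, cyclopropyl or cyclohexyl, which extends the flat response seen earlier from a three-membered to a six-membered ring of carbon only.

No supporting measurement accounts for this flat response. Going by these compounds, it remains open whether an amine, a carboxylic acid or a longer chain at this place would shift the number beyond the scatter.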